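A few compounds are considered here, and "the series" means these few. Any claim that something is new, unique, unknown or untested is made for them only; others in the source may bear on it.

Of the compounds shown here, three that share one core have been measured in an assay on T-REx-293 cells for inhibition of potassium channel subfamily T member 1 (Homo sapiens), read by patch clamp; a lower number here means a stronger inhibitor, a higher number a weaker inhibitor. Compound 3 `C[C@H](NC(=O)c1cc(C(F)(F)F)nn1C)c1nc(-c2ccnc(C(F)(F)F)c2)no1` gives 40 nM, the lowest of the three numbers and so the strongest inhibitor within this small set. Compound 1 `Cc1cc(-c2noc([C@H](C)NC(=O)c3cc(C(F)(F)F)nn3C)n2)ccn1` gives 165 nM in this assay, and compound 2 `CNc1cc(-c2noc([C@H](C)NC(=O)c3cc(C(F)(F)F)nn3C)n2)ccn1` gives 195 nM; the step of a 1.2-fold higher number from compound 1 to compound 2 (0.07 log units; within the scatter) shows that these two sit within the scatter of each other. Compound 4 `CO[C@@H](C)c1cc(-c2noc([C@H](C)NC(=O)c3cc(C(F)(F)F)nn3C)n2)ccn1` has not yet been measured. It differs from compound 3 in one place: 1-methoxyethyl in place of trifluoromethyl on an aromatic carbon. For the measured compounds named here, two measured steps bear on this change, since both alter the same position of the ring: a 4.1-fold lower number from compound 1 to compound 3 (0.62 log units; beyond the scatter) and a 4.9-fold lower number from compound 2 to compound 3 (0.69 log units; beyond the scatter). Because a 4.1-fold lower number from compound 1 to compound 3 (0.62 log units; beyond the scatter) and a 4.9-fold lower number from compound 2 to compound 3 (0.69 log units; beyond the scatter) both brought a modest gain when trifluoromethyl entered, removing trifluoromethyl again in compound 4 is expected to give part of that gain back. The group that enters has not itself been measured on this core, so the size of the step is uncertain, and the two other groups seen at this position ended up within the scatter of each other. Compound 4 is therefore expected to give about 120 nM, with a range from 40 nM to 350 nM. This estimate means an expected 3.0-fold higher number from compound 3 to compound 4 (0.48 log units; beyond the scatter).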

Compound 4, half-maximal inhibitory concentration: 744 nM
For compound 4 the middle estimate is 6.2-fold (0.79 log units) below the measured one; the whole stated range lies below it.
By their numbers in this assay, from the lowest: compound 3; then compounds 1 and 2 (each within the scatter of the next); then compound 4.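

In this assay, for the compounds shown here, the position next to the ring nitrogen turns out to be far more sensitive than the earlier steps showed: a 19-fold higher number from compound 3 to compound 4 (1.27 log units; beyond the scatter) is a large loss for 1-methoxyethyl in place of trifluoromethyl, although the two groups match in heavy-atom count. Losing trifluoromethyl is therefore not simply a return to one shared level for the other groups, since a 4.5-fold higher number from compound 1 to compound 4 (0.65 log units; beyond the scatter) and a 3.8-fold higher number from compound 2 to compound 4 (0.58 log units; beyond the scatter) both lie beyond the scatter and leave compound 4 the weakest inhibitor of the four. Nothing measured here explains why this group costs so much.

The compounds shown leave open whether the loss follows the oxygen, the branching carbon or the stereocentre of 1-methoxyethyl, which an ethyl group, a methoxymethyl group or the opposite stereocentre at this position could help to separate. They also leave open whether any group can match or surpass trifluoromethyl here, for example a chlorine atom or a cyclopropyl ring.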